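The source may hold more compounds than are shown below. What is called first, only, known or untested is meant among the compounds shown, and "the series" means these compounds.

Of the compounds shown here, three of a shared core have been tested in a functional assay on MKN-45 cells (Homo sapiens) for cytotoxicity, read by MTT assay, with a stated time of 72 h; on this read-out higher numbers stand for weaker inhibition and lower numbers for stronger inhibition. Compound 1 `COc1cc2c(Oc3ccc(NC(=O)c4cc(-c5ccc(F)cc5)ccn4)cc3F)ccnc2cc1OCCCN1CCN(C)CC1` gives 510 nM, compound 2 `COc1cc2c(Oc3ccc(NC(=O)c4cc(-c5ccc(C)cc5)ccn4)cc3F)ccnc2cc1OCCCN1CCCC1` gives 440 nM, and compound 3 `COc1cc2c(Oc3ccc(NC(=O)c4cc(-c5ccccc5C)ccn4)cc3F)ccnc2cc1OCCCN1CCCC1` gives 440 nM. Compound 3 thus sits level with compound 2, and its gap to compound 1 stays within the scatter, so no ordering can be read from these three. Compound 4 `COc1cc2c(Oc3ccc(NC(=O)c4cc(-c5ccc(F)cc5)ccn4)cc3F)ccnc2cc1OCCCN1CCCC1` differs from compound 3 in one place: 4-fluorophenyl in place of 2-methylphenyl on an aromatic carbon. Within the data shown here, the only measured step touching this position, no change at the digits printed from compound 2 to compound 3 (within the scatter), ran within the scatter, and compound 1 gives 510 nM while carrying the same 4-fluorophenyl group that enters compound 4. Compound 4 is therefore expected to show a 1.1-fold higher number from compound 3 to compound 4 (0.03 log units; within the scatter) in this assay. Compound 4 is estimated at 470 nM, with a likely range of 220 nM to 1000 nM.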

Compound 4, half-maximal inhibitory concentration: 350 nM
Compound 4: middle estimate off by 1.3-fold (0.13 log units), on the high side; the range from low to high includes it.
By their numbers in this assay, from the lowest: compounds 4, 2, 3 and 1 (each within the scatter of the next).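

In this assay the step of a 1.3-fold lower number from compound 3 to compound 4 (0.10 log units; within the scatter) and the step of a 1.3-fold lower number from compound 2 to compound 4 (0.10 log units; within the scatter) both stay within the scatter, so 2-methylphenyl, 4-methylphenyl and 4-fluorophenyl cannot be told apart at this position. The same holds at the end of the chain, where the step of a 1.5-fold lower number from compound 1 to compound 4 (0.16 log units; within the scatter) leaves pyrrolidin-1-yl and 4-methylpiperazin-1-yl indistinguishable. Nothing available explains these results. Still open, from the compounds shown here alone, is whether a carboxylic acid or an amine in place of the 4-fluorophenyl, or a longer chain carrying the pyrrolidin-1-yl, would produce a step beyond the scatter.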